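The source may hold more compounds than are shown below. What is called first, only, known or untested is meant among the compounds shown, and "the series" means these compounds.

Of the compounds shown here, three sharing one core have been measured so far in a physicochemical assay for solubility, at pH 6.5; on this read-out lower numbers stand for lower solubility and higher numbers for higher solubility. Compound 1 (`Cn1ncc2c(NCc3cccc(Cl)c3)nc(Cl)nc21`) reads 78000 nM, while compound 2 (`Cn1ncc2c(NCc3ccc(Cl)cc3)nc(Cl)nc21`) reads 145000 nM and compound 3 (`Cn1ncc2c(NCc3ccc(C(F)(F)F)cn3)nc(Cl)nc21`) reads 176000 nM on the same scale. The number for compound 2 lies within the usual scatter of each of the other two. Compound 4 (`Cn1ncc2c(NCc3ccc(C(F)(F)F)cc3)nc(Cl)nc21`) differs from compound 2 by trifluoromethyl in place of chloro on an aromatic carbon, para to a large group (trifluoromethyl in place of chloro on an aromatic carbon). Among the measured compounds shown here, no measured pair shows this exchange on its own, so the data give no direct size for it. A small fall in this assay, close to the usual scatter, is expected. An estimated step of a 1.5-fold lower number from compound 2 to compound 4 (0.18 log units; within the scatter) is expected. Compound 4 is therefore expected to read 95000 nM within an estimated range of 40000 nM to 180000 nM when measured.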

Compound 4, solubility: 164000 nM
The estimate for compound 4 lay 1.7-fold (0.24 log units) below the measured number; measured number inside the range.
By their numbers in this assay, from the lowest: compounds 1, 2, 4 and 3 (each within the scatter of the next, the first and the last beyond it).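

In this assay, among the compounds shown here, a 1.1-fold higher number from compound 2 to compound 4 (0.05 log units; within the scatter) lies within the scatter, giving the first direct reading of trifluoromethyl in place of chloro on this aromatic carbon. Here, a group of 4 heavy atoms in place of one of 1 heavy atom produces no difference that can be told from the scatter. Nothing available here explains this result. As far as these compounds go, whether an amine or a carboxylic acid at this same place would also read like compound 2 remains open. So does whether trifluoromethyl would behave the same way on the ring carbon that carries chloro in compound 1.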